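Trifluoromethoxy to hydroxy on a growth inhibitor

This account rests on a few compounds, and the source may have more. Where it says the series, first, only, none or still open, it means among the compounds named here.

Among the compounds with values here, in a functional assay on ZR-75-1 cells (Homo sapiens) for inhibition, read by sulforhodamine B assay (a lower number here means a stronger inhibitor of growth, a higher number a weaker inhibitor of growth), compound 2 (`Cc1ccc2[nH]c(-c3ccc(-c4ccc(-c5ccc(OC(F)(F)F)cc5)cc4)cc3)nc2c1`) gives 2410 nM as the lower of the two numbers so far, and compound 1 (`Cc1ccc2[nH]c(-c3ccc(-c4ccc(-c5ccc(N(C)C)cc5)cc4)cc3)nc2c1`) gives 7200 nM as the higher. Compound 3 (`Cc1ccc2[nH]c(-c3ccc(-c4ccc(-c5ccc(O)cc5)cc4)cc3)nc2c1`) carries hydroxy where compound 2 carries trifluoromethoxy (hydrogen in place of trifluoromethyl on an oxygen on an aromatic ring). Within the data shown here, the one measured step at this place (a 3.0-fold lower number from compound 1 to compound 2 (0.48 log units; beyond the scatter)) is modest, though beyond the scatter. It swaps a different pair of groups, so it offers only a rough guide. A similarly modest step towards a higher number is expected (a 1.7-fold higher number from compound 2 to compound 3 (0.22 log units; within the scatter)). Compound 3 is estimated at 4000 nM in this assay with a likely range (1500 nM to 10000 nM).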

Compound 3, concentration for 50% growth inhibition: 18200 nM
Beside the measured number, compound 3's estimate is 4.6-fold (0.66 log units) below it, and the stated range ends below it.
By their numbers in this assay, from the lowest: compound 2; then compound 1; then compound 3.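

Here the group on the oxygen clearly matters: in this assay hydrogen in place of trifluoromethyl gives a 7.6-fold higher number from compound 2 to compound 3 (0.88 log units; beyond the scatter) and this shift is larger than the one step seen before. Hydroxy also does worse than dimethylamino on the aromatic carbon, with a 2.5-fold higher number from compound 1 to compound 3 (0.40 log units; beyond the scatter) and so compound 3 is the weakest growth inhibitor of the three.

From the compounds shown here alone, whether methoxy, which keeps the oxygen but carries a plain methyl, would fall nearer compound 2 or compound 3 stays open. So does the outcome with a simple unsubstituted amine. Nothing available here explains these differences.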